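From Hexyl to 3-Phenoxypropyl: A Small Step Expected

The source may hold more compounds than are shown below. What is called first, only, known or untested is meant among the compounds shown, and "the series" means these compounds.

compound 1 `Cc1ccc(OCCCCN(Cc2ccc(C(=O)NO)cc2)c2ncc(-c3ccc(C)cc3)s2)cc1`: 11000 nM
compound 2 `CCCCN(Cc1ccc(C(=O)NO)cc1)c1ncc(-c2ccc(C)cc2)s1`: 4300 nM
compound 3 `CCCCCCN(Cc1ccc(C(=O)NO)cc1)c1ncc(-c2ccc(C)cc2)s1`: 7420 nM

These values come from a functional assay on HepG2 cells (Homo sapiens) for antiproliferative activity, read by MTT assay, with a stated time of 48 h; a higher number here means a weaker inhibitor of growth, a lower number a stronger inhibitor of growth. Compound 3 stands within the scatter of both other compounds, as shown by a 1.5-fold lower number from compound 1 to compound 3 (0.17 log units; within the scatter) and by a 1.7-fold higher number from compound 2 to compound 3 (0.24 log units; within the scatter). Within the data shown here, only one measured step clears the scatter, a 2.6-fold lower number from compound 1 to compound 2 (0.41 log units; beyond the scatter).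

The next compound is compound 4 `Cc1ccc(-c2cnc(N(CCCOc3ccccc3)Cc3ccc(C(=O)NO)cc3)s2)cc1`. Its difference from compound 3 is phenoxy in place of propyl on a saturated chain carbon, three bonds along the chain from a nitrogen on an aromatic ring. Put in words, this is phenoxy in place of propyl on a saturated chain carbon, three bonds along the chain from a nitrogen on an aromatic ring. Cut one bond further out, the same difference reads hexyl to 3-phenoxypropyl.

Among the measured compounds shown here, no measured step makes exactly this change. The closest is the exchange between compound 1 and compound 3, which carry 4-methylphenoxy and ethyl at the chain position compared, and that step stayed within the scatter. Compound 4 is therefore expected to show no step beyond the scatter in this assay. The expected change is a 1.1-fold higher number from compound 3 to compound 4 (0.06 log units; within the scatter). For compound 4 the estimate is 8500 nM, with an expected range of 4000 nM to 18000 nM.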

Compound 4, concentration for 50% growth inhibition: 23400 nM
For compound 4 the middle estimate is 2.8-fold (0.44 log units) below the measured one, and the stated range ends below it.
By their numbers in this assay, from the lowest: compounds 2, 3 and 1 (each within the scatter of the next, the first and the last beyond it); then compound 4.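

In this assay, among these compounds, the position had so far tolerated an exchange of 4-methylphenoxy for ethyl without a step beyond the scatter, but swapping propyl for phenoxy does register at this chain carbon (a 3.2-fold higher number from compound 3 to compound 4 (0.50 log units; beyond the scatter)). Compound 4 also stands clear of the two other compounds (a 5.4-fold higher number from compound 2 to compound 4 (0.74 log units; beyond the scatter); a 2.1-fold higher number from compound 1 to compound 4 (0.33 log units; beyond the scatter)), making it the weakest inhibitor of growth of the four, and this shows that a chain carrying an aryl ether is not enough to fix the number, since the 3-phenoxypropyl and 4-(4-methylphenoxy)butyl chains give results beyond the scatter of each other. Nothing in the data at hand accounts for this rise in the number.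

The compounds shown leave open whether the separation of compound 1 from compound 4 follows the chain length or the ring methyl, a question that an unsubstituted 4-phenoxybutyl chain would divide. They also leave open how this chain position would respond to a 3-phenylpropyl chain, which lacks the ether oxygen, or to a chain ending in an amine or a carboxylic acid.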